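This account rests on a few compounds, and the source may have more. Where it says the series, first, only, none or still open, it means among the compounds named here.

Compound 3 `Nc1nc(CCc2ccccc2)nc2cn(-c3ccccc3)nc12` carries a phenethyl group on the shared core, and in an assay on CHO cells for displacement of a labelled ligand from adenosine receptor A3 (Homo sapiens), read by scintillation counting, tested at 1 uM (a lower number here means less inhibition, a higher number more inhibition at the concentration tested (going by the name of the read-out)), compound 3 gives 17%, the second highest of the three numbers shown. Compound 1 `CC(C)c1nc(N)c2nn(-c3ccccc3)cc2n1` gives 11%, and the step is a number 6 percentage points higher from compound 1 to compound 3 (within the scatter). Compound 2 `Cc1ccc(Cc2nc(N)c3nn(-c4ccccc4)cc3n2)cc1` gives 39%, and the step is a number 22 percentage points lower from compound 2 to compound 3 (beyond the scatter). Compound 4 `Nc1nc(/C=C/c2ccccc2)nc2cn(-c3ccccc3)nc12` differs from compound 3 in one place: 2-phenylethenyl in place of phenethyl on an aromatic carbon. Among the measured compounds shown here, no measured step introduces a double bond outside aromatic rings, and of the two steps that reach compound 3 one lies within the scatter and one is modest. The step expected for compound 4 is a number 3 percentage points higher from compound 3 to compound 4 (within the scatter). The estimate for compound 4 is 20%, within a range from 5% to 40%.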

Compound 4, a percentage reported as inhibition, at one concentration (the size of the read-out at that concentration, not a potency): 25%
Compound 4: the middle estimate sits 5 percentage points below what was measured, within the range that was stated.
By their numbers in this assay, from the lowest: compounds 1, 3 and 4 (each within the scatter of the next, the first and the last beyond it); then compound 2.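

In this assay, the double bond that 2-phenylethenyl brings to the aromatic carbon between two ring nitrogen atoms gives a number 8 percentage points higher from compound 3 to compound 4 (within the scatter), so the unsaturated and saturated links cannot be told apart here. The same group does separate from isopropyl, with a number 14 percentage points higher from compound 1 to compound 4 (beyond the scatter), yet it does not match 4-methylbenzyl, with a number 14 percentage points lower from compound 2 to compound 4 (beyond the scatter). No evidence is available to explain these differences. On these data alone, what an unsubstituted benzyl, a methoxy group on the phenyl ring of 2-phenylethenyl or an amine at this carbon would give in this assay remains open.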